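A few compounds are considered here, and "the series" means these few. Any claim that something is new, unique, unknown or untested is made for them only; others in the source may bear on it.

Compound 1 `C/C(=C\c1cc(-c2ccc(F)nc2)co1)C(N)=O` gives > 50000 nM in a functional assay on BGC-823 cells (Homo sapiens) for cytotoxicity, read by CCK-8 assay, with a stated time of 24 h; a lower number here means a stronger inhibitor, a higher number a weaker inhibitor. Compound 2 `C/C(=C\c1cccc(-c2ccc(C)cc2)c1)C(N)=O` gives > 50000 nM in this assay. Compound 3 `C/C(=C\c1cc(-c2ccc(S(C)(=O)=O)cc2)cs1)C(N)=O` gives > 50000 nM in this assay.

For compound 3 the value > 50000 nM is a limit of the assay, not a measured number. The same holds for the other two compounds: every value shown is a limit (the limit of > 50000 nM in this assay, at which 3 of the 3 values shown sit), so compound 3 cannot be placed above or below them.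

Compound 4 `COc1ccc(-c2csc(/C=C(\C)C(N)=O)c2)cc1` is compound 3 with one change: methoxy in place of methylsulfonyl on an aromatic carbon. Among the compounds with values here, no step between measured compounds is known, so the size of this change cannot be read from the data. Given that compound 3 sits at the limit > 50000 nM, no step beyond the scatter is expected a step that the limit leaves unreadable from compound 3 to compound 4. Compound 4 is estimated at 60000 nM, in the range 20000 nM to 200000 nM.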

Compound 4, half-maximal inhibitory concentration: > 50000 nM
Compound 4: only a limit was reported; the forecaster's own chance of this, stated with the estimate: 80%; the middle value lies beyond the limit too.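

Within the data shown here, no step from compound 3 to compound 4 can be read, because both values are limits rather than measured numbers: the limit of > 50000 nM in this assay, at which 4 of the 4 values shown sit. The compounds shown leave open which change to the shared core, if any, would give a measurable value in this assay at all.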